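Swapping the Aryl Arm of a Thiosemicarbazone

The source may hold more compounds than are shown below. What is called first, only, known or untested is meant among the compounds shown, and "the series" means these compounds.

The series rests on a shared core seen in compound 1 `CC1=CC[C@@H]([C@@](C)(O)CCCC(C)(C)NC(=S)NN)CC1`, which in a functional assay on NCI-H460 cells (Homo sapiens) for cytotoxicity, read by sulforhodamine B assay (a higher number here means a weaker inhibitor of growth, a lower number a stronger inhibitor of growth), gives 12800 nM. Compound 2 `CC1=CC[C@@H]([C@@](C)(O)CCCC(C)(C)NC(=S)N/N=C\c2ccccc2)CC1` carries an aryl group on the terminal nitrogen and in this assay gives 38400 nM, a step of a 3.0-fold higher number from compound 1 to compound 2 (0.48 log units; beyond the scatter). Compound 3 `CC1=CC[C@@H]([C@@](C)(O)CCCC(C)(C)NC(=S)N/N=C\c2ccc(N(C)C)cc2)CC1` adds a dimethylamino group to that ring and in this assay gives 19600 nM; the step of a 2.0-fold lower number from compound 2 to compound 3 (0.29 log units; within the scatter) is small, and compound 3 stands within the scatter of both compound 1 and compound 2, so its position among the three numbers is not sharply defined.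

Compound 4 `CC1=CC[C@@H]([C@@](C)(O)CCCC(C)(C)NC(=S)N/N=C\c2ccccc2Cl)CC1` differs from compound 3 by 2-chlorophenyl in place of 4-(dimethylamino)phenyl on a carbon with a double bond to nitrogen. Among the compounds with values here, two measured steps bear on this change. The step from compound 2 to compound 3 showed that the dimethylamino group itself moved the number only within the scatter, so its loss is expected to matter little. The step from compound 1 to compound 2 showed a modest penalty for introducing the aryl arm at all, and compound 4 keeps that arm. Within the data shown here, no measured compound carries a chlorine, so that part of the change is uninformed. The step of a 1.3-fold higher number from compound 3 to compound 4 (0.12 log units; within the scatter) is therefore expected to stay within the scatter. Compound 4 is estimated at 26000 nM, with a range from 10000 nM to 65000 nM.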

Compound 4, concentration for 50% growth inhibition: 24600 nM
Compound 4: the middle estimate sits 1.1-fold (0.02 log units) above what was measured; the range from low to high includes it.
By their numbers in this assay, from the lowest: compounds 1, 3, 4 and 2 (each within the scatter of the next, the first and the last beyond it).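

In this assay, 2-chlorophenyl in place of 4-(dimethylamino)phenyl on a carbon with a double bond to nitrogen gives (a 1.3-fold higher number from compound 3 to compound 4 (0.10 log units; within the scatter)), and chloro in place of hydrogen on an aromatic carbon gives (a 1.6-fold lower number from compound 2 to compound 4 (0.19 log units; within the scatter)), so a chlorine on the aryl arm joins the dimethylamino group among the ring changes that stay within the scatter. The aryl arm itself now reads less firmly: the unsubstituted arm gave a step beyond the scatter (a 3.0-fold higher number from compound 1 to compound 2 (0.48 log units; beyond the scatter)), whereas the arm with chlorine gives one within it (a 1.9-fold higher number from compound 1 to compound 4 (0.28 log units; within the scatter)), so only compound 1 and compound 2 remain clearly separated among the four. No measurement available here accounts for these numbers.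

The shared core stays the same throughout, and the aryl arm has carried only dimethylamino and chloro, so the numbers say nothing about a carboxylic acid or a methoxy group on that ring. Going by these compounds, whether a longer chain in place of the aryl arm would give a step beyond the scatter also stays open.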